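The source may hold more compounds than are shown below. What is called first, only, known or untested is meant among the compounds shown, and "the series" means these compounds.

Measured so far in an ADME assay on HepG2 cells (Homo sapiens) for cytotoxicity, read by CellTiter-Glo and resazurin assay, with a stated time of 72 h; on this read-out lower numbers stand for an effect already at smaller amounts and higher numbers for an effect only at larger amounts of compound:

- compound 1 `CC(C)N(Cc1cccc(OCCCCCC(=O)O)c1)C(=O)c1ccc(-c2cccc3ccccc23)cc1`: > 26000 nM
- compound 2 `CC(C)N(Cc1cccc(OCCCCCC(=O)O)c1)C(=O)c1ccc(-c2c[nH]c3ccccc23)cc1`: > 26000 nM
- compound 3 `CC(C)N(Cc1cccc(OCCCCCC(=O)O)c1)C(=O)c1ccc(-c2cccc(C(F)(F)F)c2)cc1`: > 26000 nM

All three readings are limits of the assay, not numbers. Compound 3 is reported only as the limit > 26000 nM in this assay. Compound 1 is likewise reported as the limit > 26000 nM. Compound 2 is likewise reported as the limit > 26000 nM. The steps between them therefore carry no readable size: a step that the two limits leave unreadable from compound 1 to compound 2, a step that the two limits leave unreadable from compound 1 to compound 3 and a step that the two limits leave unreadable from compound 2 to compound 3, all three sitting at the limit of > 26000 nM in this assay, at which 3 of the 3 values shown sit.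

Compound 4 `CC(C)N(Cc1cccc(OCCCCCC(=O)O)c1)C(=O)c1ccc(-c2cccc(S(C)(=O)=O)c2)cc1` differs from compound 3 by methylsulfonyl in place of trifluoromethyl on an aromatic carbon. For the measured compounds named here, no measured step bears on this exchange: the three measured steps swap the whole aryl, not a substituent on it, and even those leave the direction and size unreadable. Going by the values given here, what the data offer is only that every member of the series so far, compound 1, compound 2 and compound 3, sits at the limit of this assay.

On that basis compound 4 is expected to show no step beyond the scatter, a step that the limit leaves unreadable from compound 3 to compound 4, and to be reported again most likely as a limit. The estimate for compound 4 in this assay is 40000 nM, with a range from 20000 nM to 120000 nM.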

Compound 4, half-maximal effective concentration: > 26000 nM
Compound 4 was reported as a limit; the forecaster's own chance of this, stated with the estimate: 85%; the middle value is on the limit's open side.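

In this assay compound 4 gives > 26000 nM, which is a limit and not a number. No step from compound 1, compound 2 or compound 3 to compound 4 can be read, and the whole series sits at one limit: the limit of > 26000 nM in this assay, at which 4 of the 4 values shown sit.

The compounds shown leave open at what concentration any of them reaches a half-maximal effect, and whether any of these aryl exchanges shifts it.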